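Shortening the ether chain by one carbon

The source may hold more compounds than are shown below. What is called first, only, known or untested is meant among the compounds shown, and "the series" means these compounds.

Three measured compounds share one core and differ only in the chain that hangs from its ring oxygen. Compound 1 `CCOCCOc1cccc2ccc(N)nc12` ends that chain in an ethoxy group; in an assay on cells with melanin-concentrating hormone receptor 1 (Homo sapiens) as the target, read by radioligand binding (a lower number here means a stronger inhibitor, a higher number a weaker inhibitor), compound 1 gives > 2000 nM, which is a limit of the assay rather than a number (the limit of > 2000 nM in this assay, at which 1 of the 3 values shown sits). Compound 2 `Nc1ccc2cccc(OCCC(F)(F)F)c2n1` ends the chain in a trifluoromethyl group and gives 722 nM in this assay. Compound 3 `CCCCCOc1cccc2ccc(N)nc12` carries a plain pentyl chain and gives 580 nM in this assay, the lowest of the two plain numbers, although the step of a 1.2-fold lower number from compound 2 to compound 3 (0.10 log units; within the scatter) lies within the scatter. The two steps that do stand out, an at least 2.7-fold lower number from compound 1 to compound 2 (0.44 log units; beyond the scatter) and an at least 3.4-fold lower number from compound 1 to compound 3 (0.53 log units; beyond the scatter), both replace the ethoxy end by something else.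

Compound 4 `CCCCOc1cccc2ccc(N)nc12` differs from compound 3 by hydrogen in place of methyl on a saturated chain carbon, four bonds along the chain from an oxygen on an aromatic ring, that is, butyl in place of pentyl. For the measured compounds named here, no measured step removes a single carbon from an otherwise unchanged chain; the closest guide is that a trifluoromethyl and a propyl end, of similar size, give numbers within the scatter of each other. A small change at most is therefore expected. Compound 4 is expected to give about 800 nM in this assay, somewhere between 350 nM and 2000 nM. That estimate means a 1.4-fold higher number from compound 3 to compound 4 (0.14 log units; within the scatter), a step expected to sit within the scatter.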

Compound 4, half-maximal inhibitory concentration: 789 nM
Beside the measured number, compound 4's estimate is 1.0-fold (0.01 log units) above it; the measured number falls inside the stated range.
By their numbers in this assay, from the lowest: compounds 3, 2 and 4 (each within the scatter of the next). At a limit, above all of these: compound 1.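

Taking the end methyl off the chain, butyl in place of pentyl, gives a 1.4-fold higher number from compound 3 to compound 4 (0.13 log units; within the scatter) in this assay, so across this pair the loss of one carbon from the chain end has no effect that can be told from the scatter. The same holds for a change of end group: ethyl in place of trifluoromethyl gives a 1.1-fold higher number from compound 2 to compound 4 (0.04 log units; within the scatter), so compounds 2, 3 and 4 form one group that cannot be ranked, and the sensitivity seen so far is not to small changes among these ends. Only the ethoxy end stands apart, with ethyl in its place giving an at least 2.5-fold lower number from compound 1 to compound 4 (0.40 log units; beyond the scatter), and that step is only a bound since compound 1 stands at a limit of the assay: the limit of > 2000 nM in this assay, at which 1 of the 4 values shown sits.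

The compounds shown leave open whether a hexyl chain, or a chain as short as propyl, would stay in this same group. They also leave open whether a methoxy end, an amine or a carboxylic acid on the chain would give numbers like those of compound 4 or would stand apart as the ethoxy end of compound 1 does.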